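The source may report more compounds than this note shows. Statements on the series, on what has been measured and on what is new or still open speak of the compounds shown alone.

Measured in a functional assay on MT4 cells (Homo sapiens) for cytotoxicity, read by MTT assay; a higher number here means that more compound is tolerated, a lower number that less compound is tolerated:
- compound 1 `Cc1cc(C)cc(S(=O)(=O)c2c(C(=O)NN3CCOC3=O)[nH]c3ccc(Cl)cc23)c1`: 100 uM
- compound 2 `Cc1cc(C)cc(S(=O)(=O)c2c(C(=O)NNC(C)C)[nH]c3ccc(Cl)cc23)c1`: > 100 uM (a limit, not a number)

Compound 2 stands at the limit of > 100 uM in this assay, at which 1 of the 2 values shown sits, so its place is known only as a limit. Compound 3 `CC(=O)NNC(=O)c1[nH]c2ccc(Cl)cc2c1S(=O)(=O)c1cc(C)cc(C)c1` has not yet been measured. It carries acetyl in place of isopropyl on an amine nitrogen. The acetyl adds a double bond outside aromatic rings and a hydrogen-bond acceptor.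

For the measured compounds named here, only one measured step bears on this change, and it does so indirectly. Going by these compounds, that step is a number no lower from compound 1 to compound 2 (the limit leaves the size open), and its size stays open. The closest guide is compound 1 at 100 uM, whose 2-oxo-1,3-oxazolidin-3-yl group, like acetyl, brings a carbonyl to the nitrogen. Nothing measured points to a large drop in this assay, so no change beyond the scatter is expected. The expected step is an at least 1.1-fold lower number from compound 2 to compound 3 (0.04 log units; that floor lies within the scatter), and the limit on compound 2 leaves its size uncertain. The estimate for compound 3 is 90 uM, with an expected range from 30 uM to 200 uM.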

Compound 3, half-maximal toxic concentration: > 100 uM
Compound 3: a limit, no number; the forecaster's own chance of this, stated with the estimate: 50%; middle value at least 1.1-fold (0.04 log units) away from the limit.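

In this assay compound 3 gives > 100 uM, which is a limit and not a number, so acetyl on this amine nitrogen ends up at the same limit as isopropyl, and the steps that rest on these limits cannot be sized. Acetamido in place of 2-oxo-1,3-oxazolidin-3-yl on the amide-type nitrogen gives a number no lower from compound 1 to compound 3 (the limit leaves the size open). What this adds is that a carbonyl on this nitrogen, carried by an open chain rather than a ring, does not bring the value down to a readable number, and the isopropyl and acetyl compounds cannot be told apart here: the limit of > 100 uM in this assay, at which 2 of the 3 values shown sit.

Going by these compounds, how far above the limit compound 2 and compound 3 truly lie stays open, and so does any real difference between them. Also open, on these data alone, is whether a larger group on this amine nitrogen, such as benzoyl or a longer chain like hexanoyl, or a free carboxylic acid there, would give a number below the limit.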